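The compounds below may be only part of what the source reports. "The series", "measured", "known", "first", "only" and "open" are said of these compounds alone.

Working notes on the series. Compound 1 `N=c1c(C(N)=O)cc(Cl)cn1Cc1ccccc1` in an assay on CHO-K1 cells for displacement of a labelled ligand from Alpha-1D adrenergic receptor (Homo sapiens), read by scintillation counting, with a stated time of 60 min (a higher number here means a weaker inhibitor, a lower number a stronger inhibitor), gives 30 nM. Within the data shown here, only two numbers are available in this assay; the other belongs to compound 3 `N=c1c(C(N)=O)cc(Cl)cn1Cc1ccc(Cl)cc1`, which gives 23 nM, and the two lie within the scatter of each other, as a 1.3-fold lower number from compound 1 to compound 3 (0.12 log units; within the scatter) shows for chloro in place of hydrogen on an aromatic carbon. Compound 2 `CN(C)C(=O)c1cc(Cl)cn(Cc2ccccc2)c1=N` yields only a limit, > 940 nM, in this assay. The step of an at least 31-fold higher number from compound 1 to compound 2 (1.49 log units; beyond the scatter) follows from dimethylamino in place of amino on a carbonyl carbon, and its size rests on (the limit of > 940 nM in this assay, at which 1 of the 3 values shown sits).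

Compound 4 `Cc1cccc(Cn2cc(Cl)cc(C(N)=O)c2=N)c1` differs from compound 1 by methyl in place of hydrogen on an aromatic carbon. The change sits on the same ring as the step from compound 1 to compound 3, where a small substituent on that ring left the number within the scatter; the step to compound 2, at the carbonyl, does not bear on it. Therefore no step beyond the scatter is expected in this assay, the estimated step being no change at the digits printed from compound 1 to compound 4 (within the scatter). Compound 4 is estimated at 30 nM, with a range of 12 nM to 75 nM.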

Compound 4, inhibition constant: 7.5 nM
Compound 4: middle estimate off by 4.0-fold (0.60 log units), on the high side; measured number below the stated range.
By their numbers in this assay, from the lowest: compound 4; then compounds 3 and 1 (each within the scatter of the next). At a limit, above all of these: compound 2.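

The step of a 4.0-fold lower number from compound 1 to compound 4 (0.60 log units; beyond the scatter) shows that the aromatic ring carbon meta to a large group is a place where one added methyl can matter in this assay without loss of binding. Among these compounds, on this ring the earlier compounds offered only a 1.3-fold lower number from compound 1 to compound 3 (0.12 log units; within the scatter) for chloro, while their one step beyond the scatter ran towards a higher number, at the carbonyl, and rests on a limit for compound 2; this is the first step beyond the scatter towards a lower number. No measured property shown here bears on the origin of this step.

From the compounds shown here alone, whether the gain belongs to methyl itself or would also appear with ethyl, methoxy or an amine at the same place remains open. Also open, going by these compounds, is whether methyl at another carbon of this ring gives a similar step.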